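A few compounds are considered here, and "the series" means these few. Any claim that something is new, unique, unknown or untested is made for them only; others in the source may bear on it.

Of the compounds shown here, three of a shared core have been read in a functional assay on isolated protein for agonist activity at Glucose-dependent insulinotropic receptor (Rattus norvegicus), read by HTRF and cAMP accumulation; a lower number here means a smaller maximal response, a higher number a larger maximal response. Compound 1 `CC(C)(C)OC(=O)N1CCC(O[C@H]2CC[C@H](Oc3ccc(S(C)(=O)=O)cn3)CC2)CC1` gives 108%, compound 2 `CC(C)(C)OC(=O)N1CCC(O[C@H]2CC[C@H](Oc3cnc(C#N)cn3)CC2)CC1` gives 100%, and compound 3 `C[C@H](CF)OC(=O)N1CCC(O[C@H]2CC[C@H](Oc3cnc(S(C)(=O)=O)cn3)CC2)CC1` gives 115%. Compound 3 thus shows the highest of the three numbers, although its gap to compound 1 lies within the usual scatter; only its gap to compound 2 lies beyond it.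

For the measured compounds named here, the one measured step, a number 8 percentage points lower from compound 1 to compound 2 (within the scatter), exchanges the aromatic group on the oxygen and leaves the carbamate untouched; it is within the scatter. Compound 1 and compound 3 differ in two places at once, so their values can only be set side by side: both sit near the reference.

Compound 4 `CS(=O)(=O)c1cnc(O[C@H]2CC[C@H](OC3CCN(CC4(C(F)(F)F)CCC4)CC3)CC2)cn1` differs from compound 3 in this way: a group of 9 heavy atoms (6 carbon, 3 fluorine; one four-membered non-aromatic ring of carbon only) in place of a group of 7 heavy atoms (4 carbon, 2 oxygen, 1 fluorine; no ring), on an amine nitrogen in a ring. Going by the values given here, no measured step touches the amine nitrogen of the six-membered ring, so the effect of this change is unknown from the data; what is known is that all three measured compounds reach a maximal response near or above the reference in this assay, and that the one measured change elsewhere in the molecule moved it little.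

He therefore expects compound 4 to remain a full agonist, with a step of a number 15 percentage points lower from compound 3 to compound 4 (beyond the scatter) and an estimated value of 100%, between 80% and 120%.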

Compound 4, largest response reached (Emax), in percent of the reference or control that the assay uses: 99%
Estimate against measurement, compound 4: 1 percentage points above; measured number inside the range.
By their numbers in this assay, from the lowest: compounds 4, 2, 1 and 3 (each within the scatter of the next, the first and the last beyond it).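

For the compounds shown here, the amine nitrogen in the six-membered ring is probed here for the first time, and in this assay the change to (1-(trifluoromethyl)cyclobutyl)methyl is a number 16 percentage points lower from compound 3 to compound 4 (beyond the scatter), so this position, unlike the one changed in a number 8 percentage points lower from compound 1 to compound 2 (within the scatter), can shift the maximal response beyond the scatter. Even so, compound 4 gives 99%, which shows that a high maximal response at this receptor does not depend on the group that leaves, with its double bond and its two hydrogen-bond acceptors, since the group that enters has neither and instead carries a four-membered carbon ring. The data at hand offer nothing that accounts for the size of this step.

The change replaces the whole group at once, so the shares of the cyclobutyl ring and the trifluoromethyl cannot be told apart, and a plain cyclobutylmethyl, a benzyl or an amide on the same nitrogen would be needed to separate them. The compounds shown also say nothing about potency, as only the largest response reached is given for them.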